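A few compounds are considered here, and "the series" means these few. Any claim that something is new, unique, unknown or untested is made for them only; others in the source may bear on it.

Measured in a functional assay on SK-OV-3 cells (Homo sapiens) for inhibition, read by CCK-8 assay, with a stated time of 70 h; on this read-out higher numbers stand for weaker inhibition and lower numbers for stronger inhibition:
- compound 1 `OCCOCCOCCOc1ccc(OCc2ccccc2)cc1`: 59400 nM
- compound 2 `c1ccc(COc2ccc(COc3ccc(OCCOCCNC4CCCC4)cc3)cc2)cc1`: 10000 nM

Compound 1 holds the higher of the two numbers, so it stands as the weaker inhibitor of the pair. Compound 3 `c1ccc(COc2ccc(OCCOCCNC3CCOC3)cc2)cc1` has not yet been measured. It differs from compound 1 by (oxolan-3-yl)amino in place of 2-hydroxyethoxy on a saturated chain carbon, two bonds along the chain from an oxygen on a saturated carbon. Within the data shown here, no measured step isolates a single change, so the expectation rests on thin evidence. Among the measured compounds shown here, the only lower reference is compound 2 at 10000 nM. A moderate move toward lower numbers in this assay is expected, and it may not clear the scatter. The estimate is a 2.0-fold lower number from compound 1 to compound 3 (0.30 log units; within the scatter). For compound 3 the expected value is 30000 nM, with an estimated range of 12000 nM to 70000 nM.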

Compound 3, half-maximal inhibitory concentration: 48000 nM
Compound 3: middle estimate off by 1.6-fold (0.20 log units), on the low side, within the range that was stated.
By their numbers in this assay, from the lowest: compound 2; then compounds 3 and 1 (each within the scatter of the next).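

In this assay, among these compounds, (oxolan-3-yl)amino in place of 2-hydroxyethoxy on a saturated chain carbon, two bonds along the chain from an oxygen on a saturated carbon, gives the first readable step (a 1.2-fold lower number from compound 1 to compound 3 (0.09 log units; within the scatter)). At this place, the read-out does not separate the two groups, even though the entering group brings a five-membered non-aromatic ring and a nitrogen that the leaving group lacks. No supporting data bear on this result.

Among the compounds shown here, with only this one step at this place, the separate contributions of the ring and the nitrogen remain unresolved. Going by these compounds, whether an open-chain diethylamino group, a morpholine or a carboxylic acid on the same chain carbon would give a step beyond the scatter also remains open.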